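Shortening the sulfanyl chain: compound 3 to compound 4

The source may report more compounds than this note shows. Statements on the series, on what has been measured and on what is new or still open speak of the compounds shown alone.

Compound 3 `CCCCCCCCSc1nc(N)nc2c1ncn2/C=C1/CC1(CO)CO` is one of three measured members built on the shared core. In an ADME assay on BCBL1 cells (Homo sapiens) for cytotoxicity, with a stated time of 7 days (a higher number here means that more compound is tolerated, a lower number that less compound is tolerated), compound 3 gives > 20000 nM, which is a limit of the assay and not a number. Compound 2 `CCCCNc1nc(N)nc2c1ncn2/C=C1/CC1(CO)CO` in this assay gives > 20000 nM, likewise a limit of the assay. Going by the values given here, compound 1 `Nc1nc(NC2CC2)c2ncn(/C=C3/CC3(CO)CO)c2n1` is the only member with a read number, giving 71500 nM in this assay. The steps a step that the limit leaves unreadable from compound 1 to compound 2 and a step that the limit leaves unreadable from compound 1 to compound 3 cannot be sized, and the step that the two limits leave unreadable from compound 2 to compound 3 is unreadable from both ends, because the limit of > 20000 nM in this assay, at which 2 of the 3 values shown sit, covers two of the three values. Compound 4 `CSc1nc(N)nc2c1ncn2/C=C1/CC1(CO)CO` is not yet measured; the change from compound 3 is hydrogen in place of heptyl on a saturated chain carbon bound to a sulfur. Among the compounds with values here, no measured step touches this position, and none of the recorded steps can be sized, so no step beyond the scatter is expected in either direction. The step from compound 3 to compound 4 is expected to be a step that the limit leaves unreadable from compound 3 to compound 4. For compound 4 in this assay the estimate is 50000 nM, with a range from 20000 nM to 150000 nM, and a further limit is the more likely outcome than a read number.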

Compound 4, half-maximal cytotoxic concentration: > 20000 nM
Compound 4 ended at the assay's limit; the forecaster's own chance of this, stated with the estimate: 70%; the middle value is on the limit's open side.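

Going by these compounds alone, no step linking compound 4 to compound 1, compound 2 or compound 3 can be read in this assay, as compound 4 also ends at a limit: the limit of > 20000 nM in this assay, at which 3 of the 4 values shown sit. Going by these compounds, how far compound 2, compound 3 and compound 4 lie from compound 1, or from one another, stays open.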